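Ring size at the chain-end ammonium: notes on compound 4

This account rests on a few compounds, and the source may have more. Where it says the series, first, only, none or still open, it means among the compounds named here.

Compound 1 `Cc1cc(-n2cc(C(=O)Nc3cc(F)cc(F)c3)c(=O)c3ccc(N(C)C)nc32)ccc1OCCCCCCC[N+]1(C)CCCC1` and compound 2 `Cc1cc(OCCCCCCC[N+]2(C)CCCC2)cc(-n2cc(C(=O)Nc3cc(F)cc(F)c3)c(=O)c3ccc(N(C)C)nc32)c1` are built from the same atoms joined differently; the difference between the two cores is not broken down here. In an assay on LX2 cells for inhibition of COL1A1 promoter (Homo sapiens), read by a luciferase reporter, with a stated time of 24 h, tested at 50 uM (on this read-out lower numbers stand for a weaker effect and higher numbers for a stronger effect at the one concentration tested), compound 1 gives 35.9%, and compound 2 gives 35.4%, the two numbers lying within the usual scatter of each other. Compound 3 `Cc1cc(-n2cc(C(=O)Nc3cc(F)cc(F)c3)c(=O)c3ccc(N(C)C)nc32)ccc1OCCCCCCC[N+]1(C)CCCCC1` differs from compound 1 by a group of 7 heavy atoms (6 carbon, 1 nitrogen; one six-membered non-aromatic ring with 1 hetero atom) in place of a group of 6 heavy atoms (5 carbon, 1 nitrogen; one five-membered non-aromatic ring with 1 hetero atom), on a saturated chain carbon, seven bonds along the chain from an oxygen on an aromatic ring. In this assay compound 3 gives 54.4%, which is a number 18.5 percentage points higher from compound 1 to compound 3 (beyond the scatter).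

Compound 4 `Cc1cc(OCCCCCCC[N+]2(C)CCCCC2)cc(-n2cc(C(=O)Nc3cc(F)cc(F)c3)c(=O)c3ccc(N(C)C)nc32)c1` has not yet been measured. It stands to compound 2 as compound 3 stands to compound 1: the change is a group of 7 heavy atoms (6 carbon, 1 nitrogen; one six-membered non-aromatic ring with 1 hetero atom) in place of a group of 6 heavy atoms (5 carbon, 1 nitrogen; one five-membered non-aromatic ring with 1 hetero atom), on a saturated chain carbon, seven bonds along the chain from an oxygen on an aromatic ring, the same change at the same place, occurring twice among these four compounds. In this assay the step from compound 2 to compound 4 is expected to be a number 14.6 percentage points higher from compound 2 to compound 4 (beyond the scatter). For the measured compounds named here, this expectation rests on the single step of a number 18.5 percentage points higher from compound 1 to compound 3 (beyond the scatter), tempered by its being the only instance and by the differently joined core of compound 2. Compound 4 is accordingly estimated at 50%, with a likely range from 36% to 64%.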

Compound 4, a percentage reported as inhibition, at one concentration (the size of the read-out at that concentration, not a potency): 79.7%
For compound 4 the middle estimate is 29.7 percentage points below the measured one, outside the stated range (above it).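

On the core of compound 2, the six-membered ring in place of the five-membered ring at the chain end gives a number 44.3 percentage points higher from compound 2 to compound 4 (beyond the scatter) in this assay. The direction of the change carries from one core to the other, but its size does not: the same change on two cores in this assay, a number 18.5 percentage points higher (beyond the scatter) from compound 1 to compound 3 and a number 44.3 percentage points higher (beyond the scatter) from compound 2 to compound 4, 25.8 percentage points apart, beyond the scatter of two such steps These two pairs show that the effect of this ring change depends on the core it sits on, but they do not explain that dependence, and they offer no basis for predicting the size of the step on a third core.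

Still open, going by these compounds, is whether the rise continues with a seven-membered ring at the chain end, and whether it survives replacement of the ring by an open trimethylammonium group or an uncharged tertiary amine. Also open, on these data alone, is whether a shorter or longer chain keeps the two cores this far apart, and whether full concentration series would confirm what these single-concentration readings suggest.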